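Replacing 3-carboxypyrrolidin-1-yl in compound 2

A few compounds are considered here, and "the series" means these few. Any claim that something is new, unique, unknown or untested is made for them only; others in the source may bear on it.

Compound 1 (`COc1ccc(/C=C\c2cc(OC)c(OC)c(OC)c2)cc1OCc1ccc(CN2CCCC[C@H]2C(=O)O)cc1`) gives > 10000 nM in a functional assay on MC-38 cells (Mus musculus) for antiproliferative activity, read by CCK-8 assay, with a stated time of 48 h (a higher number here means a weaker inhibitor, a lower number a stronger inhibitor), which is a limit and not a number. Compound 2 (`COc1ccc(/C=C\c2cc(OC)c(OC)c(OC)c2)cc1OCc1ccc(CN2CC[C@H](C(=O)O)C2)cc1`) gives > 10000 nM in this assay, again only a limit. Compound 2 therefore has no exact position in the series, and the evidence so far is the limit of > 10000 nM in this assay, at which 2 of the 2 values shown sit.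

Compound 3 (`COc1ccc(/C=C\c2cc(OC)c(OC)c(OC)c2)cc1OCc1ccc(CNCCN(C)C)cc1`) follows from compound 2 by (2-(dimethylamino)ethyl)amino in place of 3-carboxypyrrolidin-1-yl on a saturated chain carbon bound to an aromatic carbon, with (2-(dimethylamino)ethyl)amino in place of 3-carboxypyrrolidin-1-yl on a saturated chain carbon bound to an aromatic carbon. Among the compounds with values here, the one measured step, a step that the two limits leave unreadable from compound 1 to compound 2, exchanges one carboxy-bearing group for another and gives no size to carry over. Within the data shown here, compound 3 is the first here without such a group, so a shift toward stronger inhibition is expected, though on thin grounds. The expected step is an at least 4.0-fold lower number from compound 2 to compound 3 (0.60 log units; beyond the scatter). For compound 3 the estimated value is 2500 nM, with an expected range of 250 nM to 10000 nM.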

Compound 3, half-maximal inhibitory concentration: 1400 nM
Estimate against measurement, compound 3: 1.8-fold (0.25 log units) above; the range from low to high includes it.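

Within the data shown here, at the saturated chain carbon bound to an aromatic carbon, (2-(dimethylamino)ethyl)amino gives the first change with a readable size: an at least 7.1-fold lower number from compound 2 to compound 3 (0.85 log units; beyond the scatter), and an at least 7.1-fold lower number from compound 1 to compound 3 (0.85 log units; beyond the scatter). Compound 3 is thus the only compound shown with an exact value in this assay, and the position tolerates a change that moves the read-out beyond the scatter. Compound 1 and compound 2 remain limits and not numbers, so both steps give only a minimum size: the limit of > 10000 nM in this assay, at which 2 of the 3 values shown sit.

The compounds shown do not separate the loss of the carboxylic acid from the entry of the dimethylamino chain. A piperidin-1-yl group without the carboxylic acid, or a 3-(dimethylamino)propylamino chain, would bear on that question and on how far the chain length matters.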